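Changing the Aryl Group on the Thiocarbonyl-Bound Nitrogen

The source may hold more compounds than are shown below. What is called first, only, known or untested is meant among the compounds shown, and "the series" means these compounds.

Measured compounds:
compound 1 `COc1ccccc1NC(=S)N/N=C/c1ccc2ccccc2n1` — > 100000 nM
compound 2 `NC(=S)N/N=C/c1ccc2cccnc2n1` — > 100000 nM
compound 3 `NC(=S)N/N=C/c1nc2ccccc2s1` — 5350 nM

In a functional assay on HeLa cells (Homo sapiens) for antiproliferative activity, read by sulforhodamine B assay, with a stated time of 72 h (a higher number here means a weaker inhibitor, a lower number a stronger inhibitor), compound 1 gives > 100000 nM, which is a limit of the assay and not a number. Compound 2 gives > 100000 nM, also a limit. Compound 3 gives 5350 nM. Compound 1 therefore stands at the limit of > 100000 nM in this assay, at which 2 of the 3 values shown sit, and nothing more precise is known of it.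

Compound 4 `S=C(N/N=C/c1ccc2ccccc2n1)Nc1cccc(Cl)c1` differs from compound 1 in one place: 3-chlorophenyl in place of 2-methoxyphenyl on an amide-type nitrogen. Among the measured compounds shown here, no pair of measured compounds shows the effect of such a change, so no measured step can guide the expectation. The two aryl groups are of similar size, and the change is expected to shift this assay by little beyond the scatter, with the chance that compound 4 again falls at a limit rather than a number. Compound 4 is estimated at 80000 nM, within 20000 nM to 300000 nM, which means an expected step of an at least 1.2-fold lower number from compound 1 to compound 4 (0.09 log units; that floor lies within the scatter).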

Compound 4, half-maximal inhibitory concentration: 52500 nM
For compound 4 the middle estimate is 1.5-fold (0.18 log units) above the measured one, within the range that was stated.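

With 3-chlorophenyl in place of 2-methoxyphenyl on the amide-type nitrogen, the core of compound 1 gives a number rather than a limit in this assay, a change read as an at least 1.9-fold lower number from compound 1 to compound 4 (0.27 log units; that floor lies within the scatter). Compound 1 itself remains at a limit of the assay and not a number: the limit of > 100000 nM in this assay, at which 2 of the 4 values shown sit. Only the floor of the step is therefore known, so this pair shows that this nitrogen can carry an aryl group that gives a measurable value, but not how large the true change is.

From the compounds shown here alone, whether the number for compound 4 goes with the chlorine or with the loss of the methoxy group stays open. So does what an unsubstituted phenyl ring or a longer alkyl chain on this nitrogen would give.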